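A few compounds are considered here, and "the series" means these few. Any claim that something is new, unique, unknown or untested is made for them only; others in the source may bear on it.

Measured so far:
Compound 1 `CC(C)N(Cc1cccc(OCCCCCC(=O)O)c1)C(=O)c1ccc(-c2cccc(-c3ccccc3)c2)cc1` in an ADME assay on HEK293 cells (Homo sapiens) for cytotoxicity, read by CellTiter-Glo and resazurin assay, with a stated time of 72 h (a lower number here means that less compound is needed, a higher number that more compound is needed for the effect), gives only a limit, > 26000 nM.
Compound 2 `CC(C)N(Cc1cccc(OCCCCCC(=O)O)c1)C(=O)c1ccc(-c2cccc(O)c2)cc1` in this assay gives only a limit, > 26000 nM.
Compound 3 `CCOC(=O)CCCCCOc1cccc(CN(C(=O)c2ccc(-c3ccc4ccccc4c3)cc2)C(C)C)c1` in this assay gives only a limit, > 26000 nM.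

Among the measured compounds shown here, compound 3 therefore stands at the same limit as the other two; all three values sit at the limit of > 26000 nM in this assay, at which 3 of the 3 values shown sit, so no compound can be placed above or below another. For the measured compounds named here, the one step between measured compounds, a step that the two limits leave unreadable from compound 1 to compound 2, is left unreadable by its two limits.

Compound 4 `CCOC(=O)CCCCCOc1cccc(CN(C(=O)c2ccc(-c3ccc(C(C)=O)s3)cc2)C(C)C)c1` differs from compound 3 by 5-acetylthiophen-2-yl in place of naphthalen-2-yl on an aromatic carbon. Going by the values given here, no measured step touches this change, and the only comparable step is unreadable. Because compound 3 shows > 26000 nM and nothing measured points away from that limit, compound 4 is expected to give about 30000 nM, in the range 12000 nM to 80000 nM, a step that the limit leaves unreadable from compound 3 to compound 4 that is expected to stay within the scatter, most likely again reported only as a limit.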

Compound 4, half-maximal effective concentration: > 26000 nM
Compound 4 gave a limit, no number; the forecaster's own chance of this, stated with the estimate: 80%; the middle value does not contradict the limit.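

The step between compound 3 and compound 4 cannot be read, as both give only limits in this assay. Still open is the half-maximal effective concentration of every compound shown, and so any difference among them: the limit of > 26000 nM in this assay, at which 4 of the 4 values shown sit.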